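The compounds below may be only part of what the source reports. "The series", "measured", "known", "first", "only" and "open" are said of these compounds alone.

Measured in an in vitro ADME assay on microsomes from liver (Homo sapiens) for metabolic stability, tested at 1 uM; on this read-out lower numbers stand for a shorter-lived compound and higher numbers for a longer-lived compound:
- compound 1 `Cc1cc(/C=C/C#N)cc(C)c1Oc1cc(Nc2ccc(C#N)cc2)c(N)cc1C(N)=O`: 0.583 h
- compound 2 `Cc1cc(/C=C/C#N)cc(C)c1Oc1cc(Nc2ccc(C#N)cc2)c(N)cc1[N+](=O)[O-]`: 0.797 h
- compound 3 `COC(=O)c1cc(N)c(Nc2ccc(C#N)cc2)cc1Oc1c(C)cc(/C=C/C#N)cc1C`: 4.72 h

Compound 3 has the highest number of the three. Compound 4 `Cc1cc(/C=C/C#N)cc(C)c1Oc1cc(Nc2ccc(C#N)cc2)c(N)cc1C(F)(F)F` differs from it by one change: trifluoromethyl in place of methoxycarbonyl on an aromatic carbon. This puts trifluoromethyl in place of methoxycarbonyl on an aromatic carbon.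

Two measured steps end at compound 3 and bear on this change: a 5.9-fold higher number from compound 2 to compound 3 (0.77 log units; beyond the scatter) and an 8.1-fold higher number from compound 1 to compound 3 (0.91 log units; beyond the scatter). Both are beyond the scatter, whereas a 1.4-fold higher number from compound 1 to compound 2 (0.14 log units; within the scatter) is within it. Among the measured compounds shown here, no measured compound carries trifluoromethyl, so the guide is indirect. Only compound 3 holds methoxycarbonyl, and a drop of somewhat smaller size is expected in this assay.

The estimated step is a 3.1-fold lower number from compound 3 to compound 4 (0.50 log units; beyond the scatter). For compound 4 the estimated value is 1.5 h, with an expected range of 0.5 h to 4.5 h.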

Compound 4, half-life: 0.75 h
For compound 4 the middle estimate is 2.0-fold (0.30 log units) above the measured one; low and high end bracket the measured number.
By their numbers in this assay, from the lowest: compounds 1, 4 and 2 (each within the scatter of the next); then compound 3.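

In this assay, methoxycarbonyl now stands apart at this position: trifluoromethyl in its place gives a clear loss (a 6.3-fold lower number from compound 3 to compound 4 (0.80 log units; beyond the scatter)), whereas trifluoromethyl cannot be told from nitro (a 1.1-fold lower number from compound 2 to compound 4 (0.03 log units; within the scatter)) or carbamoyl (a 1.3-fold higher number from compound 1 to compound 4 (0.11 log units; within the scatter)). Among the four groups on this aromatic carbon, only methoxycarbonyl goes with the longer half-life. Nothing available explains this.

Open, from the compounds shown here alone, is whether the gain belongs to methoxycarbonyl alone or extends to an ethyl ester, an acetyl group or a carboxylic acid on this carbon.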